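Swapping Fluoro for Methoxy on a Shared Core

The source may hold more compounds than are shown below. What is called first, only, known or untested is meant among the compounds shown, and "the series" means these compounds.

Measured by a physicochemical assay for lipophilicity, using the shake flask method, in phosphate buffer, measured as octanol-water partition, at pH 7.4; on this read-out higher numbers stand for higher lipophilicity and lower numbers for lower lipophilicity
Compound 1 (`CC[C@H](c1ccc(C(=O)O)c(Oc2cccc(Cl)c2)c1OC)N1CCC[C@H](n2cc(C)c(=O)[nH]c2=O)C1`) gives -0.13
Compound 2 (`CCC[C@@H](c1ccc(C(=O)O)c(Oc2cccc(Cl)c2)c1OC)N1CCC[C@H](n2cc(C)c(=O)[nH]c2=O)C1`) gives 0.13
Compound 3 (`Cc1cn([C@H]2CCCN(Cc3ccc(C(=O)O)c(Oc4cccc(Cl)c4)c3F)C2)c(=O)[nH]c1=O`) gives -0.59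

Compound 3 has the lowest number of the three (-0.59), and its gaps to compound 1 and compound 2 both lie beyond the scatter. Compound 4 (`COc1c(CN2CCC[C@H](n3cc(C)c(=O)[nH]c3=O)C2)ccc(C(=O)O)c1Oc1cccc(Cl)c1`) has not yet been measured. It keeps the rest of compound 3 but has methoxy in place of fluoro on an aromatic carbon.

Going by the values given here, no measured pair shows this swap alone. Compound 1 and compound 2 also carry the methoxy, but each has an extra side chain that compound 4 lacks, so they are poor guides. The closest reference is therefore compound 3 (-0.59). In this assay only a small upward step is expected, one that stays within the scatter (a number 0.09 log units higher from compound 3 to compound 4 (within the scatter)). The estimated value for compound 4 is -0.5 (range -0.9 to -0.1).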

Compound 4, distribution coefficient: -0.77
Compound 4: the middle estimate sits 0.27 log units above what was measured, and the stated range covers the measured number.
By their numbers in this assay, from the lowest: compounds 4 and 3 (each within the scatter of the next); then compounds 1 and 2 (each within the scatter of the next).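

In this assay, methoxy in place of fluoro on this aromatic carbon, ortho to a 3-chlorophenoxy group, gives a number 0.18 log units lower from compound 3 to compound 4 (within the scatter), so the read-out does not separate these two groups at this position, even though methoxy brings an extra hydrogen-bond acceptor. Going by these compounds alone, with methoxy kept in this position, the single changes on the saturated chain carbon give larger steps: hydrogen in place of propyl gives a number 0.90 log units lower from compound 2 to compound 4 (beyond the scatter) and hydrogen in place of ethyl gives a number 0.64 log units lower from compound 1 to compound 4 (beyond the scatter). Nothing measured here explains these results.

The compounds shown leave open whether an amine or a longer chain on this aromatic carbon would give a step beyond the scatter. They also leave open whether the propyl and ethyl steps would look the same with fluoro in place of methoxy.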